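The source may report more compounds than this note shows. Statements on the series, on what has been measured and on what is new or still open speak of the compounds shown alone.

Three compounds of the shared core have so far been run in an assay for inhibition of serine/threonine-protein kinase PLK2 (Homo sapiens), read by FRET and Z'-LYTE, with a stated time of 1 h; a lower number here means a stronger inhibitor, a higher number a weaker inhibitor. Compound 1 `CCC1C(=O)N(C)c2cnc(Nc3ccc(S(=O)(=O)NCC(C)C)cc3)nc2N1c1ccn(C)n1` gives 311 nM. Compound 2 `CCCCNS(=O)(=O)c1ccc(Nc2ncc3c(n2)N(c2ccn(C)n2)C(CC)C(=O)N3C)cc1` gives 191 nM. Compound 3 `CCC1C(=O)N(C)c2cnc(Nc3ccc(S(N)(=O)=O)cc3)nc2N1c1ccn(C)n1` gives 121 nM, the lowest of the three numbers; the step of a 1.6-fold lower number from compound 2 to compound 3 (0.20 log units; within the scatter) lies within the scatter, whereas a 2.6-fold lower number from compound 1 to compound 3 (0.41 log units; beyond the scatter) lies beyond it. Compound 4 `CCC1C(=O)N(C)c2cnc(Nc3ccc(S(=O)(=O)NC)cc3)nc2N1c1ccn(C)n1` differs from compound 3 by methyl in place of hydrogen on a sulfonamide nitrogen. Among the measured compounds shown here, the steps that bear on this both put hydrogen on that same sulfonamide nitrogen: a 2.6-fold lower number from compound 1 to compound 3 (0.41 log units; beyond the scatter) and a 1.6-fold lower number from compound 2 to compound 3 (0.20 log units; within the scatter). The change to compound 4 runs the other way, so a small step towards a higher number is expected, if any, most likely within the scatter. Compound 4 is therefore estimated at 160 nM, range 80 nM to 320 nM, an expected step of a 1.3-fold higher number from compound 3 to compound 4 (0.12 log units; within the scatter).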

Compound 4, half-maximal inhibitory concentration: 71.6 nM
Beside the measured number, compound 4's estimate is 2.2-fold (0.35 log units) above it; measured number below the stated range.
By their numbers in this assay, from the lowest: compounds 4, 3, 2 and 1 (each within the scatter of the next, the first and the last beyond it).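

Methyl on the sulfonamide nitrogen is accepted: a 1.7-fold lower number from compound 3 to compound 4 (0.23 log units; within the scatter) leaves it not separable from hydrogen. Butyl, which hydrogen could not be told from, now separates from methyl, with a 2.7-fold lower number from compound 2 to compound 4 (0.43 log units; beyond the scatter) and with a 4.3-fold lower number from compound 1 to compound 4 (0.64 log units; beyond the scatter) as the step from isobutyl, so the two longer chains sit clearly apart from methyl. No measurement at hand gives a reason for these steps.

From the compounds shown here alone, whether ethyl or propyl on that nitrogen stays with methyl or moves towards butyl remains open. So does the effect of a second methyl on the same nitrogen, or of a chain ending in an amine.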